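Fluoro in place of hydroxy: compound 2 to compound 3

The source may hold more compounds than are shown below. What is called first, only, known or untested is meant among the compounds shown, and "the series" means these compounds.

Compound 1 `COc1ccc(CS(=O)(=O)/C=C/c2c(OC)cc(OC)cc2OC)cc1` is the reference of the series. In a functional assay on H157 cells (Homo sapiens) for antiproliferative activity, read by trypan blue exclusion (a lower number here means a stronger inhibitor, a higher number a weaker inhibitor), compound 1 gives 30 nM. Compound 2 `COc1ccc(CS(=O)(=O)/C=C/c2c(OC)cc(O)cc2OC)cc1` differs from it by hydrogen in place of methyl on an oxygen on an aromatic ring. In this assay compound 2 reaches only the limit of the assay, > 20000 nM. The step is an at least 660-fold higher number from compound 1 to compound 2 (2.82 log units; beyond the scatter), and its size is bounded by the limit of > 20000 nM in this assay, at which 1 of the 2 values shown sits, so the true gap may be wider still. Compound 2 therefore stands at the weak end of the two values shown, with no number of its own.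

Compound 3 `COc1ccc(CS(=O)(=O)/C=C/c2c(OC)cc(F)cc2OC)cc1` is not yet measured. It differs from compound 2 by fluoro in place of hydroxy on an aromatic carbon. For the measured compounds named here, the only measured step touching this position is the one from compound 1 to compound 2, which shows that losing the methyl on the oxygen here costs a great deal. Fluoro carries neither the methoxy of compound 1 nor the hydroxy of compound 2, so there is no direct precedent. With the hydroxy gone, compound 3 is expected to recover a substantial part of the lost activity, though not necessarily all of it. The expected step is an at least 66-fold lower number from compound 2 to compound 3 (1.82 log units; beyond the scatter). In this assay compound 3 is estimated at 300 nM, within 30 nM to 5000 nM.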

Compound 3, half-maximal inhibitory concentration: 500 nM
The estimate for compound 3 lay 1.7-fold (0.22 log units) below the measured number, and the stated range covers the measured number.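

In this assay, fluoro in place of hydroxy gives an at least 40-fold lower number from compound 2 to compound 3 (1.60 log units; beyond the scatter), so the collapse seen with hydroxy is not a general price for removing methoxy from this position. Fluoro does not fully stand in for methoxy, however, with a 17-fold higher number from compound 1 to compound 3 (1.22 log units; beyond the scatter), and the position therefore separates all three groups, with methoxy ahead of fluoro and fluoro ahead of hydroxy. The recovery from hydroxy to fluoro has only a lower bound, as compound 2 carries a limit of the assay and not a number: the limit of > 20000 nM in this assay, at which 1 of the 3 values shown sits.

The compounds shown leave open whether an amine, a chloro group or a longer chain such as ethoxy at this position would come closer to compound 1 than compound 3 does, or would fall nearer compound 2. Hydroxy and fluoro each count 1 heavy atom yet differ widely in activity, while methoxy counts 2, and three groups alone cannot show whether the order follows the hydrogen-bond donor of hydroxy, the extra heavy atom of methoxy or something else.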